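The source may report more compounds than this note shows. Statements on the series, on what has been measured and on what is new or still open speak of the compounds shown alone.

Working notes on a plasma stability series. Three compounds are measured: compound 1 `CC(C)OC(=O)[C@H](CCC(=O)C=[N+]=[N-])NC(=O)OCOC(=O)C(C)(C)C`, compound 2 `CCOC(=O)[C@H](CCC(=O)C=[N+]=[N-])NC(=O)[C@@H](N)CC(C)C` and compound 3 `CCC(OC(=O)N[C@@H](CCC(=O)C=[N+]=[N-])C(=O)OC)OC(=O)C(C)(C)C`. In an ADME assay on a cell-free system (plasma, Homo sapiens) for metabolic stability, read by LC-MS, with a stated time of 60 min, tested at 10 uM (on this read-out higher numbers stand for a more stable compound and lower numbers for a less stable compound), compound 1 gives 9%, compound 2 gives 1% and compound 3 gives 88%. Compound 2 stands lowest of the three numbers, within the scatter of compound 1 and far beyond it from compound 3. The next compound, compound 4 `CC(C)C[C@H](N)C(=O)N[C@@H](CCC(=O)C=[N+]=[N-])C(=O)OC(C)C`, is not yet measured; against compound 2 it differs by methyl in place of hydrogen on a saturated chain carbon bound to an oxygen next to a carbonyl group and a saturated chain carbon. Compound 1, which gives 9%, also carries isopropoxycarbonyl, so no step beyond the scatter is expected in this assay. The step from compound 2 to compound 4 is estimated as a number 5 percentage points higher from compound 2 to compound 4 (within the scatter). Compound 4 is expected to give 6%, in a range from 0% to 25%.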

Compound 4, percent of the compound remaining: 1%
The estimate for compound 4 lay 5 percentage points above the measured number; the measured number falls inside the stated range.
By their numbers in this assay, from the lowest: compounds 2, 4 and 1 (each within the scatter of the next); then compound 3.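

In this assay, ethoxycarbonyl to isopropoxycarbonyl gives no change at the digits printed from compound 2 to compound 4 (within the scatter). Going by these compounds alone, this is the first reading of this position on its own, as the earlier compounds differ from each other in more than one place, and one added methyl here does not move the read-out beyond the scatter. Nothing available accounts for this result.

Open, from the compounds shown here alone, is how a tert-butyl group or a longer chain on this oxygen would read. Also open, going by these compounds, is whether ethoxy to isopropoxy would read alike with a carbamate in place of the amide on the shared core.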